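The source may report more compounds than this note shows. Statements on the series, on what has been measured and on what is new or still open speak of the compounds shown alone.

Compound 1: `O=c1c2ccccc2ccn1[C@@H]1O[C@H](COP(=O)(O)OP(=O)(O)OP(=O)(O)O)[C@@H](O)[C@H]1O` — 31 nM
Compound 2: `Cc1ccc2c(=O)n([C@@H]3O[C@H](COP(=O)(O)OP(=O)(O)OP(=O)(O)O)[C@@H](O)[C@H]3O)ccc2c1` — 35 nM
Compound 3: `N#Cc1ccc2c(=O)n([C@@H]3O[C@H](COP(=O)(O)OP(=O)(O)OP(=O)(O)O)[C@@H](O)[C@H]3O)ccc2c1` — 88 nM

Three compounds share one core and were measured in a functional assay for agonist activity at P2Y purinoceptor 2 (Homo sapiens), read by FLIPR; on this read-out lower numbers stand for an effect already at smaller amounts and higher numbers for an effect only at larger amounts of compound. Compound 1 gives 31 nM in this assay, the lowest of the three numbers. Compound 2 carries a methyl in place of hydrogen on an aromatic carbon and gives 35 nM; the step is a 1.1-fold higher number from compound 1 to compound 2 (0.05 log units; within the scatter). Compound 3 carries a cyano in place of hydrogen on an aromatic carbon and gives 88 nM; the step is a 2.8-fold higher number from compound 1 to compound 3 (0.45 log units; beyond the scatter), and against compound 2 it is a 2.5-fold higher number from compound 2 to compound 3 (0.40 log units; beyond the scatter).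

Compound 4, `COc1ccc2ccn([C@@H]3O[C@H](COP(=O)(O)OP(=O)(O)OP(=O)(O)O)[C@@H](O)[C@H]3O)c(=O)c2c1`, has not been measured. It differs from compound 1 by methoxy in place of hydrogen on an aromatic carbon. Both measured steps from compound 1 bear on this change, since each puts a small group on an aromatic carbon of the same core: methyl left the number unchanged within the scatter, while cyano raised it modestly. A methoxy at this place is expected to land between these outcomes, with at most a small shift toward higher numbers. Compound 4 is therefore estimated at 40 nM, with a range from 20 nM to 90 nM. This estimate would mean a step of a 1.3-fold higher number from compound 1 to compound 4 (0.11 log units; within the scatter), expected to stay within or just beyond the scatter.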

Compound 4, half-maximal effective concentration: 26 nM
Compound 4: middle estimate off by 1.5-fold (0.19 log units), on the high side; the range from low to high includes it.
By their numbers in this assay, from the lowest: compounds 4, 1 and 2 (each within the scatter of the next); then compound 3.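

In this assay, methoxy in place of hydrogen on this aromatic carbon, meta to a fused ring and para to a fused ring, gives a 1.2-fold lower number from compound 1 to compound 4 (0.08 log units; within the scatter), so the two compounds cannot be told apart. The earlier compounds had shown this core only with methyl and cyano as added groups, and compound 4 now shows that a group with an oxygen, 2 heavy atoms and a hydrogen-bond acceptor can stand on an aromatic carbon of the six-membered carbon ring with no change beyond the scatter. Nothing available explains why the number holds here, and the data give no measured property of the methoxy group that could account for it.

What the compounds shown leave open is how far this tolerance extends, since a longer chain such as ethoxy, an amine or a carboxylic acid on the same carbon could behave quite differently. Going by these compounds, it is also open whether methyl or cyano would give the same outcome on this carbon as they do in compound 2 and compound 3, because a comparison of that kind needs compounds that differ in one place only.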